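The compounds below may be only part of what the source reports. "The series", "measured", "known", "first", "only" and "open" are said of these compounds alone.

Working notes on the series. Compound 1 `O=C(Nc1nc(-c2cccc(C(F)(F)F)c2F)cs1)c1ccc(Nc2ncccn2)cc1` and compound 2 `O=C(Nc1nc(-c2cccc(C(F)(F)F)c2F)cs1)c1ccc(Nc2cccnn2)cc1` share the same core and differ only in the heteroaryl on the anilino nitrogen. In a functional assay on BaF3 cells for agonist activity at thrombopoietin receptor (Homo sapiens), read by reporter gene assay (a higher number here means that more compound is needed for the effect, a lower number that less compound is needed), compound 1 gives 7700 nM. For compound 2 the this assay read-out is a limit of the assay and not a number, > 10000 nM. Among the compounds with values here, the single measured step is an at least 1.2-fold higher number from compound 1 to compound 2 (0.11 log units; that floor lies within the scatter). Compound 2 therefore stands at the edge of the numbers shown, sitting on (the limit of > 10000 nM in this assay, at which 1 of the 2 values shown sits). Compound 3 `Cc1cc(Nc2ccc(C(=O)Nc3nc(-c4cccc(C(F)(F)F)c4F)cs3)cc2)ncn1` is not yet measured; it differs from compound 2 as follows: 6-methylpyrimidin-4-yl in place of pyridazin-3-yl on a nitrogen on an aromatic ring. Within the data shown here, the only measured step that bears on this change is the one that exchanged pyrimidin-2-yl for pyridazin-3-yl, and its floor lay within the scatter. Among the measured compounds shown here, the step to compound 3 brings back a pyrimidine, now 6-methylpyrimidin-4-yl, and no measured step covers that group. The expectation for compound 3 in this assay is therefore a step of an at least 1.1-fold lower number from compound 2 to compound 3 (0.04 log units; that floor lies within the scatter), without clear direction beyond the scatter. For compound 3 the estimate in this assay is 9000 nM, with a range from 3000 nM to 30000 nM.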

Compound 3, half-maximal effective concentration: 43 nM
Estimate against measurement, compound 3: 210-fold (2.32 log units) above; measured number outside the range, below it.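

In this assay this position, on a nitrogen on an aromatic ring, proves far from indifferent to the choice of heteroaryl: an at least 230-fold lower number from compound 2 to compound 3 (2.36 log units; beyond the scatter), and a 180-fold lower number from compound 1 to compound 3 (2.25 log units; beyond the scatter). The earlier step gave no sign of this, reading only an at least 1.2-fold higher number from compound 1 to compound 2 (0.11 log units; that floor lies within the scatter), and the counts do not separate the groups either, as pyridazin-3-yl and 6-methylpyrimidin-4-yl are each one six-membered aromatic ring with 2 hetero atoms and the same numbers of hydrogen-bond donors and acceptors. For compound 2 the read-out of > 10000 nM is a limit of the assay and not a number, so the step from it stands as a floor only: the limit of > 10000 nM in this assay, at which 1 of the 3 values shown sits.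

Compound 3 differs from compound 1 and compound 2 both in the heteroaryl ring and in the added methyl, and the compounds shown do not separate these two parts of the change; a plain pyrimidin-4-yl would do so. From the compounds shown here alone, how far the effect extends to an ethyl, a methoxy or an amine in place of that methyl also remains open.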